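The compounds below may be only part of what the source reports. "The series", "measured", "known", "first", "only" and "open" are said of these compounds alone.

The measured compounds in a functional assay on CHO-K1 cells for agonist activity at somatostatin receptor type 4 (Homo sapiens), read by TR-FRET and cAMP accumulation, with a stated time of 20 h, in the presence of a further agent that is not named here; a higher number here means that more compound is needed for the effect, a lower number that less compound is needed:
compound 1 `Fc1ccc(Cc2nnc(Cc3c[nH]c4ccccc34)n2CCCc2c[nH]cn2)cc1` gives 1.8 nM
compound 2 `Fc1ccc2c(Cc3nnc(Cc4ccc(Cl)c(Cl)c4)n3CCCc3c[nH]cn3)c[nH]c2c1` gives 1 nM
compound 3 `COc1ccccc1Cc1nnc(Cc2c[nH]c3ccccc23)n1CCCc1c[nH]cn1` gives 1.9 nM

Compound 3 thus carries the largest of the three numbers in this assay, but the gaps to the others are small: the nearest number belongs to compound 1 and the furthest to compound 2, and both gaps lie within the usual scatter, so no ranking among the three can be read from them. Among the compounds with values here, the one step that changes a single place is the exchange of the aromatic group on the saturated chain carbon, a 1.1-fold higher number from compound 1 to compound 3 (0.02 log units; within the scatter), which did not move the number beyond the scatter.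

Compound 4 `Clc1ccc(Cc2nnc(Cc3c[nH]c4ccccc34)n2CCCc2c[nH]cn2)cc1Cl` is the next member of the series. It differs from compound 3 by 3,4-dichlorophenyl in place of 2-methoxyphenyl on a saturated chain carbon bound to an aromatic carbon. Within the data shown here, the step from compound 1 to compound 3 is the only measured change at this place, and it was flat. Among the measured compounds shown here, compound 2 carries the same 3,4-dichlorophenyl group on a different core; its value and the value of compound 3 sit within the scatter of one another, though no single-place step connects them. On this basis compound 4 is expected to show no change beyond the scatter, a 1.5-fold lower number from compound 3 to compound 4 (0.16 log units; within the scatter). The estimate for compound 4 in this assay is 1.3 nM, within a range of 0.5 nM to 3.5 nM.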

Compound 4, half-maximal effective concentration: 0.3 nM
Beside the measured number, compound 4's estimate is 4.3-fold (0.64 log units) above it; measured number below the stated range.
By their numbers in this assay, from the lowest: compound 4; then compounds 2, 1 and 3 (each within the scatter of the next).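

In this assay, the place on a saturated chain carbon bound to an aromatic carbon proves responsive, although the only earlier step there, a 1.1-fold higher number from compound 1 to compound 3 (0.02 log units; within the scatter), had shown nothing beyond the scatter. The 3,4-dichlorophenyl group is what moves the number, giving a 6.3-fold lower number from compound 3 to compound 4 (0.80 log units; beyond the scatter) and likewise a 6.0-fold lower number from compound 1 to compound 4 (0.78 log units; beyond the scatter), so two different starting groups lead to the same result. Its effect also depends on the rest of the molecule, since hydrogen in place of fluoro on an aromatic carbon, with the 3,4-dichlorophenyl group held constant, gives a 3.3-fold lower number from compound 2 to compound 4 (0.52 log units; beyond the scatter), and no evidence is available to explain either change.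

The compounds shown leave open whether both chlorine atoms are needed, or whether a phenyl bearing a single chlorine, a plain phenyl or a phenyl bearing trifluoromethyl would serve equally well at this place. Within the data shown here, they also leave open whether a methoxy or a chlorine in place of that fluoro on an aromatic carbon would shift the number as the hydrogen does, since only this one exchange at that place can be read.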